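The source may hold more compounds than are shown below. What is called first, only, known or untested is meant among the compounds shown, and "the series" means these compounds.

Measured compounds:

compound 1 `Cc1ccc(Nc2nccc(-c3ccnc4ccccc34)n2)cc1`: 1400 nM
compound 2 `FC(F)(F)c1ccc(Nc2nccc(-c3ccnc4ccccc34)n2)cc1`: 1720 nM
compound 3 `Cc1ccc(Nc2nccc(-c3c(C)nc4ccccn34)n2)cc1`: 19.7 nM

All three numbers come from a functional assay on SK-LU-1 cells (Homo sapiens) for cytotoxicity, read by sulforhodamine B assay, with a stated time of 48 h; a lower number here means a stronger inhibitor, a higher number a weaker inhibitor. Compound 1 and compound 2 share one core and differ by trifluoromethyl in place of methyl on an aromatic carbon; the step of a 1.2-fold higher number from compound 1 to compound 2 (0.09 log units; within the scatter) is small, so these two compounds cannot be separated from each other. Compound 3 sits on a different core; how the two cores differ is not broken down here. Compound 3 gives the lowest number of the three, and its gap to compound 1 and to compound 2 lies well beyond the scatter, so compound 3 is the most potent of the measured set in this assay.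

Compound 4 `Cc1nc2ccccn2c1-c1ccnc(Nc2ccc(C(F)(F)F)cc2)n1` is not yet measured. It is made from compound 3 by trifluoromethyl in place of methyl on an aromatic carbon, the same change, at the same place, as from compound 1 to compound 2. Since that earlier step, a 1.2-fold higher number from compound 1 to compound 2 (0.09 log units; within the scatter), stayed within the scatter, the expectation is that compound 4 will also stay close to compound 3, with an estimated step of a 1.2-fold higher number from compound 3 to compound 4 (0.09 log units; within the scatter). The estimate for compound 4 in this assay is therefore 24 nM, expected to fall between 9 nM and 65 nM.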

Compound 4, half-maximal inhibitory concentration: 34 nM
The estimate for compound 4 lay 1.4-fold (0.15 log units) below the measured number, within the range that was stated.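

In this assay, trifluoromethyl in place of methyl on an aromatic carbon gives a 1.7-fold higher number from compound 3 to compound 4 (0.24 log units; within the scatter), and the two cores can be compared directly: the same change on two cores in this assay, a 1.2-fold higher number (0.09 log units; within the scatter) from compound 1 to compound 2 and a 1.7-fold higher number (0.24 log units; within the scatter) from compound 3 to compound 4, 1.4-fold (0.15 log units) apart, within the scatter of two such steps

On both cores, then, this exchange gives a step that cannot be told from the scatter, and the two steps cannot be told from each other, so the earlier result carries over to the second core. Among the compounds shown here, the support is only two matched pairs, with the change at one place, para to a large group, so it does not show that the same would hold on a further core or at another place on the ring, and it gives no reason for the result.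

The compounds shown carry only methyl or trifluoromethyl at this place, so it remains open how chlorine, a methoxy group, a nitrile or an amine there would read on either core. Also open, on these data alone, is whether a longer chain, such as propyl, would stay as close to these compounds as trifluoromethyl does to methyl.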